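The compounds below may be only part of what the source reports. "The series", "measured", "known", "first", "only" and "open" are said of these compounds alone.

In an assay on HEK293 cells for displacement of a labelled ligand from 5-hydroxytryptamine receptor 7 (Rattus norvegicus) (on this read-out lower numbers stand for stronger inhibition and higher numbers for weaker inhibition), compound 1 `COc1ccc(OC)c(N2CCN(CCCCCC(=O)NC3CCCc4ccccc43)CC2)c1` gives 70.3 nM, and compound 2 `N#Cc1ccc(N2CCN(CCCCCC(=O)NC3CCCc4ccccc43)CC2)cc1` gives 1400 nM, the highest of the two numbers measured. Within the data shown here, the single measured step, a 20-fold higher number from compound 1 to compound 2 (1.30 log units; beyond the scatter), is the one comparison that bears on the next change, since it also swapped the aryl group on the same ring nitrogen. Compound 3 `CC(=O)c1cccc(N2CCN(CCCCCC(=O)NC3CCCc4ccccc43)CC2)c1` differs from compound 2 by 3-acetylphenyl in place of 4-cyanophenyl on an amine nitrogen in a ring. Among the measured compounds shown here, with no acetyl-bearing compound measured, compound 3 is expected to move only modestly, if at all, giving the step of a 1.6-fold lower number from compound 2 to compound 3 (0.19 log units; within the scatter). For compound 3 the estimated value is 900 nM, expected to lie between 250 nM and 3000 nM.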

Compound 3, inhibition constant: 496 nM
Compound 3: the middle estimate sits 1.8-fold (0.26 log units) above what was measured, and the stated range covers the measured number.
By their numbers in this assay, from the lowest: compound 1; then compound 3; then compound 2.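

In this assay the step of a 2.8-fold lower number from compound 2 to compound 3 (0.45 log units; beyond the scatter) shows that this position on the ring nitrogen still responds when one substituted phenyl group replaces another, neither of them 2,5-dimethoxyphenyl. The step of a 7.1-fold higher number from compound 1 to compound 3 (0.85 log units; beyond the scatter) is smaller than the earlier change to 4-cyanophenyl, yet 2,5-dimethoxyphenyl still gives the lowest number of the three. Nothing measured here explains these differences. The compounds shown leave open whether the identity of the substituent or its place on the phenyl ring carries the step, and how an unsubstituted phenyl or a pyridine ring on the same nitrogen would compare.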